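Compound 3 to compound 4: a change of configuration

The source may report more compounds than this note shows. Statements on the series, on what has been measured and on what is new or still open speak of the compounds shown alone.

In an ADME assay on microsomes from liver (Rattus norvegicus) for metabolic stability, with a stated time of 10 min (a lower number here means that less of the compound is left, a higher number that more of the compound is left), compound 3 `COc1ccccc1-n1nc([C@@H]2CCO[C@@H](C(C)C)C2)cc1-c1ccc(Cl)cc1` gives 14%, level with compound 2 `COc1ccccc1-n1nc(C2C[C@H](C)O[C@@H](C)C2)cc1-c1ccc(Cl)cc1` at 14%. Compound 1 `COc1ccccc1-n1nc([C@H]2C[C@@H](C)O[C@@H](C)C2)cc1-c1ccc(Cl)cc1` gives 18%, within the scatter of both. Compound 4 `COc1ccccc1-n1nc([C@@H]2CCO[C@H](C(C)C)C2)cc1-c1ccc(Cl)cc1` has the same atoms and bonds as compound 3 and differs only in configuration as drawn: the two compounds have the same atoms and bonds and differ only in configuration as drawn: 1 of 2 stereo elements differ; a stereocentre at a saturated ring carbon is drawn R in compound 3 and S in compound 4. Within the data shown here, the one measured configurational step is a number 4 percentage points lower from compound 1 to compound 2 (within the scatter). Its reading is limited by the fact that one of compounds 1 and 2 is drawn with a defined configuration and the other without, at the place where they differ. The group exchanges, a number 4 percentage points lower from compound 1 to compound 3 (within the scatter) and no change at the digits printed from compound 2 to compound 3 (within the scatter), also stay small. Among the measured compounds shown here, with a number 4 percentage points lower from compound 1 to compound 2 (within the scatter) as the nearest precedent, no step beyond the scatter is expected. The expected step is a number 1 percentage points higher from compound 3 to compound 4 (within the scatter). Compound 4 is estimated at 15%, with an expected range of 7% to 27%.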

Compound 4, percent of the compound remaining: 21%
Beside the measured number, compound 4's estimate is 6 percentage points below it, and the stated range covers the measured number.
By their numbers in this assay, from the lowest: compounds 2, 3, 1 and 4 (each within the scatter of the next).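

In this assay, among these compounds, a number 7 percentage points higher from compound 3 to compound 4 (within the scatter) is the first step that reads configuration alone at this saturated ring carbon: the fact that compounds 3 and 4 differ only in the configuration as drawn. The earlier configurational step could not be read so cleanly: the fact that one of compounds 1 and 2 is drawn with a defined configuration and the other without, at the place where they differ. The group exchanges with compound 4 as partner, a number 7 percentage points higher from compound 2 to compound 4 (within the scatter) and a number 3 percentage points higher from compound 1 to compound 4 (within the scatter), stay equally small, so neither this configuration nor 2-isopropyloxan-4-yl in place of 2,6-dimethyloxan-4-yl separates these compounds.

Open, from the compounds shown here alone, is whether any group on this aromatic carbon gives a step beyond the scatter, for example an amine or a carboxylic acid in place of 2-isopropyloxan-4-yl.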